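Methyl on the Ring Amide Nitrogen Weakens Cell Inhibition

This account rests on a few compounds, and the source may have more. Where it says the series, first, only, none or still open, it means among the compounds named here.

Compound 1, `CC1CCN(c2ccc(Nc3ncc4c(n3)N(C3CCCC3)CC(=O)N4)cc2)CC1`, gives 8430 nM in a functional assay on HCT-116 cells (Homo sapiens) for inhibition, read by MTT assay, with a stated time of 48 h; on this read-out lower numbers stand for stronger inhibition and higher numbers for weaker inhibition.
Compound 2, `CN1CCN(c2ccc(Nc3ncc4c(n3)N(C3CCCC3)CC(=O)N4)nc2)CC1`, gives only a limit, not a number, in this assay: > 30000 nM.
Compound 3, `CC1CCN(c2ccc(Nc3ncc4c(n3)N(C3CCCC3)CC(=O)N4C)cc2)CC1`, gives 25300 nM in this assay.

Compound 1 and compound 3 share a core and differ in a single place, (methyl in place of hydrogen on an amide-type nitrogen in a ring), and a 3.0-fold higher number from compound 1 to compound 3 (0.48 log units; beyond the scatter). How the core of compound 1 differs from the core of compound 2 is not broken down here. Compound 4, `CN1CCN(c2ccc(Nc3ncc4c(n3)N(C3CCCC3)CC(=O)N4C)nc2)CC1`, has not yet been measured; it differs from compound 2 by methyl in place of hydrogen on an amide-type nitrogen in a ring, the same change as that between compound 1 and compound 3. Compound 2 already sits at the limit of > 30000 nM in this assay, at which 1 of the 3 values shown sits, so the same change would be expected to carry compound 4 further in the direction of weaker inhibition, and most likely the assay would again report only a limit. Compound 4 is therefore expected to give about 70000 nM, somewhere between 30000 nM and 200000 nM. The step that this estimate means is a step that the limit leaves unreadable from compound 2 to compound 4, expected to be roughly as large as the measured one.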

Compound 4, half-maximal inhibitory concentration: 9730 nM
Compound 4: middle estimate off by 7.2-fold (0.86 log units), on the high side, outside the stated range (below it).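

Read against the limit of compound 2, methyl in place of the amide hydrogen gives an at least 3.0-fold lower number from compound 2 to compound 4 (0.48 log units; beyond the scatter) in this assay, so on this core the change goes with stronger inhibition, not weaker. Set beside the earlier step, the same change does not carry over from one core to the other, and its direction turns around: the same change on two cores in this assay, a 3.0-fold higher number (0.48 log units; beyond the scatter) from compound 1 to compound 3 and an at least 3.0-fold lower number (0.48 log units; beyond the scatter) from compound 2 to compound 4, at least 9.2-fold (0.96 log units) apart, beyond the scatter of two such steps

This shows that what this methyl does in the series depends on the core that carries it, but with one pair per core and no breakdown of how the two cores differ, it does not show which part of the core decides the outcome, or why.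

On these data alone, whether an ethyl group or a longer chain on the same amide nitrogen would follow the pattern of compound 3 or that of compound 4 remains open. Among these compounds, it is also open how the methyl would behave on any further core, since only two cores appear here.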